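Swapping fluoro for bromo in a cytotoxicity series

The source may report more compounds than this note shows. Statements on the series, on what has been measured and on what is new or still open speak of the compounds shown alone.

Compound 1 `CNC(=O)c1cc(Oc2ccc(C3=NNC(c4ccc(C#N)cc4)C3)cc2)ccn1` gives 17400 nM
Compound 2 `CNC(=O)c1cc(Oc2ccc(C3=NNC(c4ccc(F)cc4)C3)cc2)ccn1` gives 15100 nM

Both values come from a functional assay on A549 cells (Homo sapiens) for cytotoxicity, read by MTT assay, with a stated time of 72 h (on this read-out lower numbers stand for stronger inhibition and higher numbers for weaker inhibition), and the two compounds cannot be told apart there. Going by the values given here, compound 2 has only one measured neighbour, and the link between them is a 1.2-fold lower number from compound 1 to compound 2 (0.06 log units; within the scatter) when fluoro replaces cyano on an aromatic carbon.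

Compound 3 `CNC(=O)c1cc(Oc2ccc(C3=NNC(c4ccc(Br)cc4)C3)cc2)ccn1` differs from compound 2 in one place. The change is bromo in place of fluoro on an aromatic carbon, counted in full as bromo in place of fluoro on an aromatic carbon while the rest of the molecule stays the same.

Among the compounds with values here, the only measured guide is that single swap at the same place on the ring, which gave a 1.2-fold lower number from compound 1 to compound 2 (0.06 log units; within the scatter) and so moved the number by no more than repeat measurements do. Within the data shown here, one step is thin evidence, and no bromo compound has been measured yet. No shift in either direction is therefore expected beyond the scatter in this assay for this swap. The estimate means a 1.1-fold lower number from compound 2 to compound 3 (0.03 log units; within the scatter) and so an expected change of no real size. Compound 3 is estimated at 14000 nM with an expected range from 7000 nM to 28000 nM on this read-out.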

Compound 3, half-maximal inhibitory concentration: 21000 nM
The estimate for compound 3 lay 1.5-fold (0.18 log units) below the measured number; the measured number falls inside the stated range.
By their numbers in this assay, from the lowest: compounds 2, 1 and 3 (each within the scatter of the next).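

With bromo on the aromatic carbon para to a large group, this position has now carried three different substituents, and in this assay no swap among them gives a difference larger than repeat measurements would. Fluoro to bromo gives a 1.4-fold higher number from compound 2 to compound 3 (0.14 log units; within the scatter), and cyano to bromo gives a 1.2-fold higher number from compound 1 to compound 3 (0.08 log units; within the scatter), so the earlier cyano-to-fluoro step is no longer the only sign that this read-out cannot separate the compounds. No other measurement is available to explain why the three compounds read alike.

Still open, on these data alone, is whether an amine, a carboxylic acid or a longer chain such as ethoxy on this same carbon would move the number beyond the scatter, since fluoro, cyano and bromo cover only a small part of what could sit there. Also open, as far as these compounds go, are how a plain hydrogen at this carbon would compare and whether the same lack of separation would hold in cells other than the single line used here.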